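The source may hold more compounds than are shown below. What is called first, only, known or untested is meant among the compounds shown, and "the series" means these compounds.

Measured so far in an ADME assay on microsomes from liver (Mus musculus) for metabolic stability, with a stated time of 10 min; a lower number here means that less of the compound is left, a higher number that more of the compound is left:
- compound 1 `O=C(O)[C@H]1CC[C@H](C(=O)N2CC[C@](c3ccc(C(F)(C(F)(F)F)C(F)(F)F)cc3)(S(=O)(=O)c3ccccc3)C2)CC1`: 96%
- compound 2 `Cc1ccc(S(=O)(=O)[C@@]2(c3ccc(C(F)(C(F)(F)F)C(F)(F)F)cc3)CCN(C(=O)[C@H]3CC[C@H](C(=O)O)CC3)C2)cc1`: 85%

Of these two, compound 2 has the lower number, at 85%, so it is the starting point with less of the compound left. The next structure is compound 3 `CCc1ccc(S(=O)(=O)[C@@]2(c3ccc(C(F)(C(F)(F)F)C(F)(F)F)cc3)CCN(C(=O)[C@H]3CC[C@H](C(=O)O)CC3)C2)cc1`, and it differs in one place: methyl in place of hydrogen on a saturated chain carbon bound to an aromatic carbon. Here methyl replaces hydrogen on a saturated chain carbon bound to an aromatic carbon, which turns 4-methylphenyl into 4-ethylphenyl.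

Within the data shown here, only one measured step bears on this change: a number 11 percentage points lower from compound 1 to compound 2 (beyond the scatter). That modest step also put methyl in place of hydrogen, but on an aromatic carbon, so it is a loose guide and a single case shows no pattern. A small further fall in this assay is therefore expected, of about that size or less, and it may not stand clear of the usual scatter. The expected change is a number 7 percentage points lower from compound 2 to compound 3 (within the scatter). For compound 3 the estimate is 78%, with an expected range of 62% to 90%.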

Compound 3, percent of the compound remaining: 100%
Compound 3: middle estimate off by 22 percentage points, on the low side, outside the stated range (above it).
By their numbers in this assay, from the lowest: compound 2; then compounds 1 and 3 (each within the scatter of the next).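

In this assay the change from 4-methylphenyl to 4-ethylphenyl gives a number 15 percentage points higher from compound 2 to compound 3 (beyond the scatter), so adding a methyl does not have the same outcome at each place: the earlier step on an aromatic carbon, a number 11 percentage points lower from compound 1 to compound 2 (beyond the scatter), went the other way. The comparison with hydrogen shows a number 4 percentage points higher from compound 1 to compound 3 (within the scatter), so with ethyl in place of that hydrogen the fall seen with methyl does not appear, and the number stays level with the unsubstituted compound within the scatter. The data shown offer no measured explanation for why methyl and ethyl part ways here.

Going by these compounds, whether a longer chain such as propyl, a branched group such as isopropyl or an oxygen-linked group such as methoxy would sit with the methyl or with the ethyl compound remains open. On these data alone, each of these steps is also a single case on one shared core, so it is unknown whether the same contrast between methyl and ethyl would appear on another core.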